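A few compounds are considered here, and "the series" means these few. Any claim that something is new, unique, unknown or untested is made for them only; others in the source may bear on it.

Compound 1 `N=C(NCCCc1c[nH]cn1)NC(=O)CC(c1ccccc1)c1ccccn1` gives 97% in a functional assay on cardiac atrium for agonist activity at histamine H2 receptor (Cavia porcellus); on this read-out higher numbers stand for larger maximal responses and lower numbers for smaller maximal responses
Compound 2 `N=C(NCCCc1c[nH]cn1)NC(=O)CC(c1ccccc1)c1nccs1` gives 100% in this assay
Compound 3 `CC(CC(=O)NC(=N)NCCCc1c[nH]cn1)c1ccccn1` gives 98% in this assay

The three values lie within the usual scatter of one another. Between compound 1 and compound 2 the change is 1,3-thiazol-2-yl in place of pyridin-2-yl on a saturated chain carbon bound to an aromatic carbon and a saturated chain carbon, and its step was a number 3 percentage points higher from compound 1 to compound 2 (within the scatter). Compound 4 `CC(CC(=O)NC(=N)NCCCc1c[nH]cn1)c1nccs1` has not yet been measured in this assay. It arises from compound 3 by 1,3-thiazol-2-yl in place of pyridin-2-yl on a saturated chain carbon bound to two saturated chain carbons. The cores of compound 3 and compound 1 differ by methyl in place of phenyl on a saturated chain carbon bound to an aromatic carbon and a saturated chain carbon, so the place of the exchange differs: in compound 1 the carbon is bound to an aromatic carbon and a saturated chain carbon, in compound 3 to two saturated chain carbons. It is the same kind of change, not the same. The expected step is a number 1 percentage points higher from compound 3 to compound 4 (within the scatter), because a number 3 percentage points higher from compound 1 to compound 2 (within the scatter) stayed within the scatter. Compound 4 is estimated at 99%, between 90% and 106%.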

Compound 4, largest response reached (Emax), in percent of the reference or control that the assay uses: 91%
Estimate against measurement, compound 4: 8 percentage points above, and the stated range covers the measured number.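

Putting 1,3-thiazol-2-yl in place of pyridin-2-yl on the core of compound 3 gives a number 7 percentage points lower from compound 3 to compound 4 (within the scatter), and this exchange does not act measurably differently on the two cores: the same change on two cores in this assay, a number 3 percentage points higher (within the scatter) from compound 1 to compound 2 and a number 7 percentage points lower (within the scatter) from compound 3 to compound 4, 10 percentage points apart, within the scatter of two such steps. Methyl in place of phenyl gives a number 9 percentage points lower from compound 2 to compound 4 (within the scatter), and that change also carries over within the scatter: the same change on two cores in this assay, a number 1 percentage points higher (within the scatter) from compound 1 to compound 3 and a number 9 percentage points lower (within the scatter) from compound 2 to compound 4, 10 percentage points apart, within the scatter of two such steps. In this assay these four compounds therefore show both changes carrying over from one core to the other, but they do not show that either change would behave the same way on any further core.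

As far as these compounds go, it remains open whether an amine or a carboxylic acid on that saturated chain carbon would leave the maximal response as it is. The same question stands for a longer chain in place of methyl.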